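The compounds below may be only part of what the source reports. "The series", "measured", "known", "first", "only" and "open" are said of these compounds alone.

Measured in a functional assay on HCT-15 cells (Homo sapiens) for cytotoxicity, read by colorimetric assay and MTT assay; on this read-out lower numbers stand for stronger inhibition and higher numbers for weaker inhibition:
- Compound 1 `COc1cc(OC)c2cc(-c3ccc(OCc4ccccc4)cc3)c(O)nc2c1`: 10000 nM
- Compound 2 `COc1ccc(-c2cc3c(OC)cc(OC)cc3n(CC#N)c2=O)cc1`: 10000 nM

Compound 2, at 10000 nM, stands level with compound 1, at 10000 nM, within the usual scatter of this assay. Compound 3 `COc1ccc(-c2cc3c(OC)cc(OC)cc3n(CC(=O)O)c2=O)cc1` departs from compound 2 in one place: carboxy in place of cyano on a saturated chain carbon bound to an aromatic nitrogen. Put in words, it carries carboxy in place of cyano on a saturated chain carbon bound to an aromatic nitrogen. Among the measured compounds shown here, no measured pair in this small set differs in one place, so the data offer no direct guide to this change. The expectation in this assay is therefore for no step beyond the scatter, with any small shift more likely towards weaker inhibition. The expected step is a 1.2-fold higher number from compound 2 to compound 3 (0.08 log units; within the scatter). For compound 3, the estimate is 12000 nM, with an expected range of 5000 nM to 30000 nM.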

Compound 3, half-maximal inhibitory concentration: 10000 nM
Estimate against measurement, compound 3: 1.2-fold (0.08 log units) above; low and high end bracket the measured number.
By their numbers in this assay, from the lowest: compounds 1, 2 and 3 (each within the scatter of the next).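

In this assay, among the compounds shown here, putting carboxy in place of cyano on a saturated chain carbon bound to an aromatic nitrogen brings no change at the digits printed from compound 2 to compound 3 (within the scatter) and gives the first reading in this set of a change made in one place. At this position, cyanomethyl and carboxymethyl cannot be told apart on this read-out, even though the exchange adds a hydrogen-bond donor to the chain. Nothing available here explains this result.

As far as these compounds go, whether an amine, a methyl ester or a primary amide on that chain carbon would read any differently stays open, as does the effect of a longer chain carrying the carboxy group. The compounds shown also leave open whether any group at this place can move the number away from the level shared by compound 2 and compound 3.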